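The source may hold more compounds than are shown below. What is called first, only, known or untested is meant among the compounds shown, and "the series" means these compounds.

Measured so far:
compound 1, `O=C(CSc1nnnn1-c1cccc2ccccc12)N/N=C/c1ccco1`, in an ADME assay on MT4 cells (Homo sapiens) for cytotoxicity, read by MTT assay (a lower number here means that less compound is tolerated, a higher number that more compound is tolerated), gives > 330000 nM.
compound 2, `O=C(CSc1nnnn1-c1cccc2ccccc12)N/N=C/c1ccc(F)cc1`, in this assay gives > 307000 nM.

For compound 1 the value is a limit of this assay, not a number. For compound 2 the value is likewise a limit. The step from one to the other is therefore a step that the two limits leave unreadable from compound 1 to compound 2. Compound 3, `COc1ccc(/C=N/NC(=O)CSc2nnnn2-c2cccc3ccccc23)c(OC)c1`, differs from compound 1 thus: 2,4-dimethoxyphenyl in place of furan-2-yl on a carbon with a double bond to nitrogen. Only limits exist, at the limit of > 330000 nM in this assay, at which 1 of the 2 values shown sits, and at the limit of > 307000 nM in this assay, at which 1 of the 2 values shown sits, so no size of step can be read from them. Compound 3 is expected to stay at the limit as well, giving an estimated 320000 nM (range 150000 nM to 700000 nM), that is an expected step of an at least 1.0-fold lower number from compound 1 to compound 3 (0.01 log units; that floor lies within the scatter).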

Compound 3, half-maximal cytotoxic concentration: 28300 nM
Compound 3: the middle estimate sits 11-fold (1.05 log units) above what was measured; the measured number lies below the stated range.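

Changing the group on a carbon with a double bond to nitrogen gives an at least 11-fold lower number from compound 1 to compound 3 (1.06 log units; beyond the scatter), and the same place gives an at least 10-fold lower number from compound 2 to compound 3 (1.03 log units; beyond the scatter). The values of compound 1 and compound 2 are limits, so each step gives only a floor on its size. Even so, this place is not indifferent in this assay: with the shared core unchanged, 2,4-dimethoxyphenyl is the only group shown that yields a number rather than a limit, and less compound is tolerated. As far as these compounds go, whether both methoxy groups are needed stays open, as does what a single methoxy group or a dimethylamino group on the phenyl ring would give.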